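Carboxylate placement and a methylene insertion on the amide nitrogen

This account rests on a few compounds, and the source may have more. Where it says the series, first, only, none or still open, it means among the compounds named here.

Measured compounds:
compound 1 `CCCCCCCCCCOc1cc(OCCCCCCCCCC)cc(OCCCCCC(=O)N(c2ccc(C(=O)OC)cc2)c2ccc(C(=O)OC)c(C(=O)OC)c2)c1` — 95%
compound 2 `CCCCCCCCCCOc1cc(OCCCCCCCCCC)cc(OCCCCCC(=O)N(c2cccc(C(=O)O)c2)c2cccc(C(=O)O)c2)c1` — 14%
compound 3 `CCCCCCCCCCOc1cc(OCCCCCCCCCC)cc(OCCCCCC(=O)N(c2ccc(C(=O)O)cc2)c2cccc(C(=O)O)c2)c1` — 53%

In an assay on isolated protein for binding affinity to L-selectin (Homo sapiens), read by ELISA, tested at 500 uM (a lower number here means less inhibition, a higher number more inhibition at the concentration tested (going by the name of the read-out)), compound 3 gives 53%, the second highest of the three numbers. Its nearest neighbour is compound 2, which in this assay gives 14%; the furthest is compound 1 with 95%. Within the data shown here, the one step recorded between compounds that differ in a single place is a number 39 percentage points higher from compound 2 to compound 3 (beyond the scatter), a large change for swapping 4-carboxyphenyl for 3-carboxyphenyl on the amide-type nitrogen.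

Compound 4 `CCCCCCCCCCOc1cc(OCCCCCCCCCC)cc(OCCCCCC(=O)N(Cc2ccc(C(=O)O)cc2)c2cccc(C(=O)O)c2)c1` is not yet measured. It differs from compound 3 as follows: 4-carboxybenzyl in place of 4-carboxyphenyl on an amide-type nitrogen. Among the measured compounds shown here, no measured step covers this change. For the measured compounds named here, the only step that bears on it at all is a number 39 percentage points higher from compound 2 to compound 3 (beyond the scatter), which shows that this assay responds strongly to how the carboxyl-bearing aryl group is arranged on the amide-type nitrogen, but it does not say in which direction a 4-carboxybenzyl would move the number. Given that, compound 4 is expected to land somewhat below compound 3, with wide uncertainty: the estimated step is a number 8 percentage points lower from compound 3 to compound 4 (within the scatter). The estimate for compound 4 is 45%, within a range from 15% to 80%.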

Compound 4, a percentage reported as inhibition, at one concentration (the size of the read-out at that concentration, not a potency): 92%
Compound 4: middle estimate off by 47 percentage points, on the low side; measured number outside the range, above it.
By their numbers in this assay, from the lowest: compound 2; then compound 3; then compounds 4 and 1 (each within the scatter of the next).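

In this assay, the result shows that at this position the link between the amide-type nitrogen and the ring matters, not only where the carboxyl group sits on the ring: a number 39 percentage points higher from compound 3 to compound 4 (beyond the scatter) for 4-carboxybenzyl in place of 4-carboxyphenyl, a change of one heavy atom, a carbon, with the same counts of rings, hydrogen-bond donors and acceptors. Measured against the 3-carboxyphenyl group of compound 2, the same 4-carboxybenzyl group gives a number 78 percentage points higher from compound 2 to compound 4 (beyond the scatter), so the single added carbon moves the number about as far as the earlier change in carboxyl placement, which was a number 39 percentage points higher from compound 2 to compound 3 (beyond the scatter). Nothing measured here explains why one added carbon has so large an effect.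

The compounds shown leave open whether the gain depends on the carboxyl group staying at the position named in 4-carboxybenzyl, which a 3-carboxybenzyl group would test, and whether a longer chain, such as 2-(4-carboxyphenyl)ethyl, would hold the number. They also leave open whether the carboxylic acid on the benzyl ring is needed at all, since a plain benzyl group or an aminomethyl group on that ring would answer this.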